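Chlorophenyl to Fluorophenyl on a Shared Core

The compounds below may be only part of what the source reports. "The series", "measured", "known", "first", "only" and "open" are said of these compounds alone.

In a functional assay on DU-145 cells (Homo sapiens) for cytotoxicity, read by sulforhodamine B assay, with a stated time of 48 h (on this read-out lower numbers stand for stronger inhibition and higher numbers for weaker inhibition), compound 1 `C[C@H]1CC[C@@H]2[C@@H](OC(=O)[C@]23CC(c2ccc(Cl)cc2)=NO3)[C@]2(C)C(=O)C=C[C@@]12O` gives 43000 nM, and compound 2 `C[C@H]1CC[C@@H]2[C@@H](OC(=O)[C@]23CC(c2ccccc2Cl)=NO3)[C@]2(C)C(=O)C=C[C@@]12O` gives 19000 nM, the lower of the two numbers. Compound 3 `C[C@H]1CC[C@@H]2[C@@H](OC(=O)[C@]23CC(c2ccc(F)cc2)=NO3)[C@]2(C)C(=O)C=C[C@@]12O` carries 4-fluorophenyl in place of 2-chlorophenyl on a carbon with a double bond to nitrogen. Among the compounds with values here, only one measured step bears on this change, a 2.3-fold lower number from compound 1 to compound 2 (0.35 log units; beyond the scatter), which is modest. Within the data shown here, no fluorinated compound has been measured yet. Compound 1, with its 4-chlorophenyl, is the closest guide, so a modest rise is expected, reversing much of that step. The expected step is a 1.8-fold higher number from compound 2 to compound 3 (0.27 log units; within the scatter). In this assay compound 3 is estimated at 35000 nM, within a range of 14000 nM to 80000 nM.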

Compound 3, half-maximal inhibitory concentration: 13000 nM
Estimate against measurement, compound 3: 2.7-fold (0.43 log units) above, and the stated range ends above it.
By their numbers in this assay, from the lowest: compounds 3 and 2 (each within the scatter of the next); then compound 1.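

In this assay the change from 2-chlorophenyl to 4-fluorophenyl gives a 1.5-fold lower number from compound 2 to compound 3 (0.16 log units; within the scatter) and so does not separate these two groups at this position. Fluoro in place of chloro on an aromatic carbon gives a 3.3-fold lower number from compound 1 to compound 3 (0.52 log units; beyond the scatter) and shows that the halogen on the 4-substituted phenyl alone can move the number beyond the scatter. No measured evidence accounts for either step. The compounds shown leave open how a plain phenyl, or a phenyl bearing an amine or a carboxylic acid, would compare on the shared core.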